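The source may hold more compounds than are shown below. What is called first, only, known or untested is meant among the compounds shown, and "the series" means these compounds.

Compound 1 (`CCc1c(SC)nc2nc(C(=O)c3ccccc3)cn2c1C`) and compound 2 (`CCc1c(OC)nc2nc(C(=O)c3ccccc3)cn2c1C`) share one core and differ at a single place. In a functional assay on the whole organism with Mus musculus as the target (a lower number here means that less compound is needed, a higher number that more compound is needed for the effect), compound 1 gives 200 mg/kg and compound 2 gives 200 mg/kg, so compound 2 stands level with compound 1. Within the data shown here, the only measured step, where methoxy takes the place of methylsulfanyl on an aromatic carbon, shows no change at the digits printed from compound 1 to compound 2 (within the scatter).

Compound 3 (`CCCc1c(OC)nc2nc(C(=O)c3ccccc3)cn2c1C`) differs from compound 2 by turning ethyl into propyl: methyl in place of hydrogen on a saturated chain carbon, two bonds along the chain from an aromatic carbon. In words, this is methyl in place of hydrogen on a saturated chain carbon, two bonds along the chain from an aromatic carbon.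

Among the measured compounds shown here, no measured step touches this chain, so the data offer no direct evidence on the change. The step that showed no change at the digits printed from compound 1 to compound 2 (within the scatter) lies at a different place and is only a weak guide, based on a single pair. The best anchor is therefore compound 2 at 200 mg/kg. The expected step in this assay is no change at the digits printed from compound 2 to compound 3 (within the scatter), with no direction favoured and nothing expected beyond the scatter. For compound 3 the estimated value is 200 mg/kg, with an expected range from 100 mg/kg to 400 mg/kg.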

Compound 3, dose for half-maximal effect: 100 mg/kg
Compound 3: middle estimate off by 2.0-fold (0.30 log units), on the high side; the measured number falls inside the stated range.
By their numbers in this assay, from the lowest: compounds 3, 1 and 2 (each within the scatter of the next).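

In this assay, extending the ethyl chain to propyl, which is methyl in place of hydrogen on a saturated chain carbon, two bonds along the chain from an aromatic carbon, gives a 2.0-fold lower number from compound 2 to compound 3 (0.30 log units; within the scatter) and so stays inside the usual spread of repeat measurements. Among these compounds, this is the first reading at this chain, since the earlier pair varied only the methoxy and methylsulfanyl place, and it shows that this one added carbon leaves the dose needed within the scatter, though a single pair is thin support for any wider statement about the position. Nothing measured here bears on what lies behind this result.

The compounds shown leave open whether a longer chain such as butyl, a branched group such as isopropyl, or a chain ending in an amine would move the number beyond the scatter at this position. They also leave open whether propyl would read the same with methylsulfanyl in place of methoxy, as the two places have so far been compared only one at a time.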